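Swapping Iodo for Bromo on a Pyrazoline Aryl Ring

The compounds below may be only part of what the source reports. "The series", "measured", "known", "first", "only" and "open" are said of these compounds alone.

The measured compounds and their values:
compound 1 `Ic1ccc(C2CC(c3ccc4c(c3)OCCO4)=NN2c2ccccc2)cc1` 3470 nM
compound 2 `Oc1ccccc1C1CC(c2ccc(Cl)c(Cl)c2)=NN1c1ccccc1` 1570 nM
compound 3 `Cc1ccc(C2CC(c3ccc4c(c3)OCCO4)=NN2c2ccccc2)cc1` 2530 nM

In a functional assay on WM 266-4 cells (Homo sapiens) for antiproliferative activity, read by MTT assay, with a stated time of 24 h (on this read-out lower numbers stand for stronger inhibition of growth and higher numbers for weaker inhibition of growth), compound 1 gives 3470 nM, the highest of the three numbers. Its nearest neighbour is compound 3, which in this assay gives 2530 nM; the step of a 1.4-fold lower number from compound 1 to compound 3 (0.14 log units; within the scatter) is within the scatter. Within the data shown here, compound 2, in this assay, gives 1570 nM, which lies beyond the scatter from compound 1, but compound 2 differs from compound 1 in several places and no single step links them.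

Compound 4 `Brc1ccc(C2CC(c3ccc4c(c3)OCCO4)=NN2c2ccccc2)cc1` has not yet been measured. It differs from compound 1 only in this way: bromo in place of iodo on an aromatic carbon. Among the measured compounds shown here, the one measured step that bears on a change at this position, a 1.4-fold lower number from compound 1 to compound 3 (0.14 log units; within the scatter), was within the scatter, and no step shows a swap of one halogen for another. Compound 4 is therefore expected to stay close to compound 1, with a step of a 1.1-fold lower number from compound 1 to compound 4 (0.04 log units; within the scatter) that is expected to be within the scatter. In this assay compound 4 is estimated at 3200 nM, in a range from 1600 nM to 6400 nM.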

Compound 4, concentration for 50% growth inhibition: 3010 nM
For compound 4 the middle estimate is 1.1-fold (0.03 log units) above the measured one, and the stated range covers the measured number.
By their numbers in this assay, from the lowest: compounds 2, 3, 4 and 1 (each within the scatter of the next, the first and the last beyond it).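

In this assay, among these compounds, the first swap of one halogen for another at this position gives a 1.2-fold lower number from compound 1 to compound 4 (0.06 log units; within the scatter) and so does not separate 4-iodophenyl from 4-bromophenyl. The step of a 1.2-fold higher number from compound 3 to compound 4 (0.08 log units; within the scatter) likewise shows no separation, so iodo, bromo and methyl on this aromatic carbon, para to a large group, cannot be told apart on the shared core of these three compounds. Nothing available offers a reason for this sameness.

The compounds shown leave open whether an amine, a carboxylic acid or a longer alkyl chain at this position would shift the number beyond the scatter. They also leave open whether fluoro or chloro here would stay as close to compound 1 as bromo does.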